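Methoxy on the pendant phenyl: cytotoxicity notes on the series

The source may report more compounds than this note shows. Statements on the series, on what has been measured and on what is new or still open speak of the compounds shown alone.

Compound 1 `CC1=C(C(=O)Nc2ccc(Cl)cc2)C(c2ccccc2)C(C(=O)Nc2ccc(Cl)cc2)=C(C)N1` and compound 2 `COc1ccc(C2C(C(=O)Nc3ccc(Cl)cc3)=C(C)NC(C)=C2C(=O)Nc2ccc(Cl)cc2)cc1` share one core, while compound 3 `COc1ccc(NC(=O)C2=C(C)NC(=S)NC2c2ccccc2)cc1` is built on another; the difference between the two cores is not broken down here. In an ADME assay on Vero cells (Chlorocebus sabaeus) for cytotoxicity, read by sulforhodamine B assay, with a stated time of 3 days (on this read-out higher numbers stand for lower toxicity in this test and lower numbers for higher toxicity in this test), compound 1 gives 15 ug/mL, and in this assay compound 2 gives 20 ug/mL. Within the data shown here, the single change between these two is methoxy in place of hydrogen on an aromatic carbon, and it made a 1.3-fold higher number from compound 1 to compound 2 (0.12 log units; within the scatter). In this assay compound 3 gives 15 ug/mL, which is level with compound 1 at the digits shown and lies within the scatter of compound 2 as well.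

Compound 4 `COc1ccc(NC(=O)C2=C(C)NC(=S)NC2c2ccc(OC)cc2)cc1` has not yet been measured. It differs from compound 3 by methoxy in place of hydrogen on an aromatic carbon, the same change already seen on the first core; among the compounds here it occurs two times in all, and both times at a place described in identical words. On the first core the change stayed within the scatter. Among the measured compounds shown here, only that one pair is available, and it sits on a different core, so a carry-over to compound 3 is untested. The step from compound 3 to compound 4 in this assay is expected to be a 1.1-fold higher number from compound 3 to compound 4 (0.05 log units; within the scatter), of a size comparable to the earlier one, because a 1.3-fold higher number from compound 1 to compound 2 (0.12 log units; within the scatter) was small. Compound 4 is accordingly estimated at 17 ug/mL, with a range from 8 ug/mL to 35 ug/mL expected.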

Compound 4, half-maximal cytotoxic concentration: 150 ug/mL
For compound 4 the middle estimate is 8.8-fold (0.95 log units) below the measured one; the measured number lies above the stated range.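

In this assay, phenyl to 4-methoxyphenyl on the thione-free comparison is not the same event on both cores, and the step on the second core is a 10-fold higher number from compound 3 to compound 4 (1.00 log units; beyond the scatter), set against the earlier one as follows: the same change on two cores in this assay, a 1.3-fold higher number (0.12 log units; within the scatter) from compound 1 to compound 2 and a 10-fold higher number (1.00 log units; beyond the scatter) from compound 3 to compound 4, 7.5-fold (0.88 log units) apart, beyond the scatter of two such steps The size of the step therefore did not carry from the core of compound 1 to the core of compound 3, so a step read on one core in this series is a poor guide to the size of the same change on the other. This does not show what sets the two steps apart, since the cores differ in more than one place and each core offers a single pair, and two pairs fix no rule for any further core.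

On the core of compound 4, which gives 150 ug/mL, the compounds shown leave open whether the large step belongs to methoxy alone or would also appear with a hydroxy group, an ethoxy group or an amine at the same place. Among these compounds, also open is whether the methoxy on the other aromatic ring of that core has any part in the size of the step, as no pair here varies it.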